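This account rests on a few compounds, and the source may have more. Where it says the series, first, only, none or still open, it means among the compounds named here.

Measured compounds:
compound 1 `COc1ccc(OCCCON2C(N)=NC(N)=NC23CCOCC3)cc1` — > 90%
compound 2 `NC1=NC2(CCSCC2)N(OCCCOc2cccc(Cl)c2)C(N)=N1` — 88.3%

In an assay on isolated protein for inhibition of Dihydrofolate reductase (Homo sapiens), read by spectrophotometry, using NADPH, with stated times of 5 s and 6 min, tested at 5 uM (on this read-out lower numbers stand for a weaker effect and higher numbers for a stronger effect at the one concentration tested), compound 1 reaches the limit of the read-out, so only a bound and no number is known for it (the limit of > 90% in this assay, at which 1 of the 2 values shown sits). Compound 2 gives 88.3% in this assay. Compound 3 `NC1=NC2(CCOCC2)N(OCCCOc2cccc(Cl)c2)C(N)=N1` is not yet measured. It differs from compound 1 by 3-chlorophenyl in place of 4-methoxyphenyl on an oxygen on a saturated carbon. Among the compounds with values here, with no measured step to go on, the expectation for compound 3 is a change in this assay no larger than the scatter, so the estimated step of a number no higher from compound 1 to compound 3 (the limit leaves the size open) is small. Compound 3 is expected to give about 90%, between 78% and 97%.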

Compound 3, a percentage reported as inhibition, at one concentration (the size of the read-out at that concentration, not a potency): 83.2%
For compound 3 the middle estimate is 6.8 percentage points above the measured one; low and high end bracket the measured number.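

In this assay, 3-chlorophenyl in place of 4-methoxyphenyl on an oxygen on a saturated carbon gives a number at least 6.8 percentage points lower from compound 1 to compound 3 (that floor lies within the scatter). Within the data shown here, this is the first reading of a change at this position alone, and compound 3 still gives 83.2%, so a high read-out at the one concentration tested does not depend on 4-methoxyphenyl. The true size of the step stays open, since the value for compound 1 is only a limit: the limit of > 90% in this assay, at which 1 of the 3 values shown sits.

The compounds shown leave open how an amine or a carboxylic acid on the phenyl ring would read in this assay. They also leave open the effect of a longer chain between the oxygen and the phenyl ring.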